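Moving the Ring Nitrogen in an Acid Ceramidase Series

A few compounds are considered here, and "the series" means these few. Any claim that something is new, unique, unknown or untested is made for them only; others in the source may bear on it.

Of the compounds shown here, three sharing one core have been tested in an assay on isolated protein for inhibition of acid ceramidase (Homo sapiens), read by LC-MS, with a stated time of 1 h; a higher number here means a weaker inhibitor, a lower number a stronger inhibitor. Compound 1 `O=C(NCCCCc1ccccc1)n1cc(-c2ccc(Cl)cc2)oc1=O` gives 83 nM. Compound 2 `O=C(NCCCCc1ccccc1)n1cc(-c2ccc(F)cc2)oc1=O` gives 185 nM, and the change from compound 1 is a 2.2-fold higher number from compound 1 to compound 2 (0.35 log units; beyond the scatter). Compound 3 `O=C(NCCCCc1ccccc1)n1cc(-c2ccccn2)oc1=O` gives 25 nM, the lowest of the three numbers; the step of a 3.3-fold lower number from compound 1 to compound 3 (0.52 log units; beyond the scatter) and the step of a 7.4-fold lower number from compound 2 to compound 3 (0.87 log units; beyond the scatter) are both beyond the scatter, so compound 3 is the strongest inhibitor of this set.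

Compound 4 `O=C(NCCCCc1ccccc1)n1cc(-c2ccncc2)oc1=O` differs from compound 3 by pyridin-4-yl in place of pyridin-2-yl on an aromatic carbon. Within the data shown here, no measured step bears directly on this change: the steps of a 3.3-fold lower number from compound 1 to compound 3 (0.52 log units; beyond the scatter) and a 7.4-fold lower number from compound 2 to compound 3 (0.87 log units; beyond the scatter) show that the identity of the aromatic ring matters to a modest degree, but neither compares two pyridines. A moderate loss is therefore expected, with wide uncertainty, amounting to a 2.4-fold higher number from compound 3 to compound 4 (0.38 log units; beyond the scatter). In this assay compound 4 is estimated at 60 nM, between 15 nM and 250 nM.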

Compound 4, half-maximal inhibitory concentration: 18 nM
Estimate against measurement, compound 4: 3.3-fold (0.52 log units) above, within the range that was stated.
By their numbers in this assay, from the lowest: compounds 4 and 3 (each within the scatter of the next); then compound 1; then compound 2.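

In this assay, pyridin-4-yl in place of pyridin-2-yl gives a 1.4-fold lower number from compound 3 to compound 4 (0.14 log units; within the scatter), so the two placements of the ring nitrogen cannot be told apart at this position. Compared with the halogenated phenyl compounds, pyridin-4-yl gives a 4.6-fold lower number from compound 1 to compound 4 (0.66 log units; beyond the scatter) and a 10-fold lower number from compound 2 to compound 4 (1.01 log units; beyond the scatter), the second of these a large step, so both pyridines shown give lower numbers than compound 1 and compound 2. Nothing available explains why the placement of the nitrogen makes so little difference here.

The compounds shown leave open where pyridin-3-yl, the remaining placement of the nitrogen, would fall. They also include no unsubstituted phenyl, so the gain over compound 1 and compound 2 cannot be divided between adding a ring nitrogen and removing the halogen.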